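The compounds below may be only part of what the source reports. "The series", "measured", "known", "first", "only" and "open" are said of these compounds alone.

Measured compounds in the series:

- compound 1, `CCCCCC(=O)Nc1cc2nc(C3CCCCC3)[nH]c2cc1N1CCCC1`: > 100 ug/mL
- compound 2, `CCN(CC)c1cc2[nH]c(C3CCCCC3)nc2cc1NC(=O)OCC(F)(F)F`: > 100 ug/mL
- compound 3, `CCCCCC(=O)Nc1cc2nc(C3CCCCC3)[nH]c2cc1N(CC)CC`: "not determined" (no result reported)

Three compounds of the shared core have been run in an ADME assay on Vero cells (Chlorocebus sabaeus) for cytotoxicity, read by resazurin assay, with a stated time of 3 days; on this read-out higher numbers stand for weaker inhibition and lower numbers for stronger inhibition. Compound 1 returns > 100 ug/mL, which is a limit of the assay and not a number. Compound 2 likewise returns > 100 ug/mL, again a limit. For compound 3 no result has been reported, so it stands on no number of its own; what frames it is the limit of > 100 ug/mL in this assay, at which 2 of the 3 values shown sit, which is where the two values that do exist sit.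

The step from compound 3 to compound 4, `CCN(CC)c1cc2[nH]c(C3CCCCC3)nc2cc1NC(=O)c1ccc(OC(F)(F)F)cc1`, is 4-(trifluoromethoxy)phenyl in place of pentyl on a carbonyl carbon. The rest of the molecule, including the diethylamino group and the cyclohexyl-bearing core, is unchanged. Among the compounds with values here, no measured pair in this set differs in a single place, so no step size is known for this assay. Given that both measured values sit at the limit, the expectation is no shift beyond the scatter in this assay, and most likely a third result at that limit.

On that basis compound 4 is expected to give about 100 ug/mL in this assay, within a range from 40 ug/mL to 200 ug/mL, with the result most probably reported as a limit rather than a number.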

Compound 4, half-maximal inhibitory concentration: > 100 ug/mL
Compound 4 gave a limit, no number; the forecaster's own chance of this, stated with the estimate: 75%; the middle value lies on the limit itself.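

Compound 2 and compound 4 both return limits, not numbers, in this assay, and the step between them, 4-(trifluoromethoxy)phenyl in place of 2,2,2-trifluoroethoxy on a carbonyl carbon, cannot be read. The compounds shown leave open whether any change on the carbonyl carbon moves a value away from what frames the series so far: the limit of > 100 ug/mL in this assay, at which 3 of the 4 values shown sit.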